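Methoxy for hydrogen on the sulfonamide aryl ring

The source may hold more compounds than are shown below. What is called first, only, known or untested is meant among the compounds shown, and "the series" means these compounds.

Measured compounds:
compound 1, `CC(=O)SCC(=O)c1ccc(NS(=O)(=O)c2ccccc2)cc1`, 15400 nM
compound 2, `CC(=O)SCC(=O)c1ccc(NS(=O)(=O)c2ccc(F)cc2)cc1`, "not determined" (no result reported)

For the measured compounds named here, compound 1 is the only compound of the series with a number: in a functional assay on HCT-116 cells (Homo sapiens) for cytotoxicity (a higher number here means that more compound is needed for the effect, a lower number that less compound is needed), compound 1 gives 15400 nM. Compound 2 has no result reported in this assay, so nothing can be said of its standing.

Compound 3, `COc1ccc(S(=O)(=O)Nc2ccc(C(=O)CSC(C)=O)cc2)cc1`, differs from compound 1 in one place: methoxy in place of hydrogen on an aromatic carbon. Going by the values given here, no step between two measured compounds is available, so the effect of this change has no precedent. The expectation for compound 3 is that the step of a 1.2-fold lower number from compound 1 to compound 3 (0.07 log units; within the scatter) stays within the usual scatter, with no clear direction. On that basis compound 3 is estimated at 13000 nM in this assay, with a range from 4000 nM to 45000 nM.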

Compound 3, half-maximal effective concentration: 500 nM
The estimate for compound 3 lay 26-fold (1.41 log units) above the measured number; the measured number lies below the stated range.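

In this assay, for the compounds shown here, methoxy in place of hydrogen gives a 31-fold lower number from compound 1 to compound 3 (1.49 log units; beyond the scatter), the only step that can be read. It shows that this place on the aromatic ring, para to a large group, responds strongly to substitution, which compound 1 alone could not show. This is one pair on one core, and no available data bear on the reason for the step.

The step to compound 2 cannot be read, so the fluoro compound adds nothing on how other groups behave at this place. On these data alone, whether a hydroxy group, an ethoxy group, a longer alkoxy chain or an amine at the same place would give a step of similar size stays open, as does the effect of methoxy elsewhere on the ring.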